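The source may report more compounds than this note shows. Statements on the series, on what has been measured and on what is new or still open speak of the compounds shown alone.

In a functional assay on MGC-803 cells (Homo sapiens) for antiproliferative activity, read by MTT assay, with a stated time of 72 h (a higher number here means a weaker inhibitor, a lower number a stronger inhibitor), three compounds that share one core have been measured. Compound 1 `CCCSc1nc(N/N=C/c2ccc(C)cc2)c2nnn(Cc3ccccc3)c2n1` gives > 64000 nM, and this is a limit of the assay, not a number. Compound 2 `CCCSc1nc(N/N=C/c2cccnc2)c2nnn(Cc3ccccc3)c2n1` gives 38100 nM. Compound 3 `CCCSc1nc(N/N=C(\C)c2ccccc2O)c2nnn(Cc3ccccc3)c2n1` gives 2310 nM, the lowest number of the three, which makes it the strongest inhibitor here.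

Compound 4 `CCCSc1nc(N/N=C/c2ccc(Br)cc2)c2nnn(Cc3ccccc3)c2n1` has not been measured yet. Its difference from compound 3 is a group of 9 heavy atoms (7 carbon, 1 nitrogen, 1 bromine; one six-membered aromatic ring of carbon only) in place of a group of 10 heavy atoms (8 carbon, 1 nitrogen, 1 oxygen; one six-membered aromatic ring of carbon only), on a nitrogen on an aromatic ring. The closest evidence comes from two large steps that replace a group at this same place and end at compound 3: an at least 27-fold lower number from compound 1 to compound 3 (1.44 log units; beyond the scatter) and a 16-fold lower number from compound 2 to compound 3 (1.22 log units; beyond the scatter). The step of an at least 1.6-fold lower number from compound 1 to compound 2 (0.22 log units; that floor lies within the scatter) stays within the scatter. Like compound 1 and compound 2, compound 4 lacks the group of 10 heavy atoms that compound 3 carries, so a large move back towards a weaker inhibitor seems likely.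

The expected step in this assay is a 13-fold higher number from compound 3 to compound 4 (1.11 log units; beyond the scatter). Compound 4 is estimated at 30000 nM, with an expected range of 9000 nM to 64000 nM.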

Compound 4, half-maximal inhibitory concentration: 34900 nM
Compound 4: middle estimate off by 1.2-fold (0.07 log units), on the low side, within the range that was stated.
By their numbers in this assay, from the lowest: compound 3; then compounds 4 and 2 (each within the scatter of the next). At a limit, above all of these: compound 1.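

Compound 4 adds a third group at this place, on a nitrogen on an aromatic ring, and it too lacks the oxygen-bearing group of compound 3 (a 15-fold higher number from compound 3 to compound 4 (1.18 log units; beyond the scatter)), so the large gap to compound 3 now holds for a bromine-bearing ring as well. The 4-bromophenyl and pyridin-3-yl groups cannot be told apart in this assay (a 1.1-fold lower number from compound 2 to compound 4 (0.04 log units; within the scatter)), so these two different rings give the same result within the scatter. Bromo in place of methyl gives only a floor (an at least 1.8-fold lower number from compound 1 to compound 4 (0.26 log units; that floor lies within the scatter)), because the value of compound 1 is a limit of the assay and not a number: the limit of > 64000 nM in this assay, at which 1 of the 4 values shown sits.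

The compounds shown leave open which feature of compound 3, its oxygen or its extra carbon, goes with its lower number. They also leave open what a methoxy or an amino group on that aromatic ring would give.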